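A few compounds are considered here, and "the series" means these few. Any claim that something is new, unique, unknown or untested is made for them only; others in the source may bear on it.

Compound 3, `CNC(=O)c1ncc(-c2cnc(NCc3c(F)ccc4c3CCO4)c3cn[nH]c(=O)c23)n1C`, is one of three compounds sharing a common core and differing only in the group on one aromatic carbon. In an ADME assay on microsomes from liver (Homo sapiens) for metabolic stability, read by LC-MS, using NADPH, with stated times of 5 min and 30 min, tested at 1 uM (a higher number here means faster removal of the compound, a lower number slower removal), compound 3 gives 24 mL.min-1.g-1, level with compound 1, `Cc1cc(-c2cnc(NCc3c(F)ccc4c3CCO4)c3cn[nH]c(=O)c23)n(C)n1`, which gives 24 mL.min-1.g-1; together they are the highest of the three numbers. Compound 2, `Cc1nc(CN(C)C)ccc1-c1cnc(NCc2c(F)ccc3c2CCO3)c2cn[nH]c(=O)c12`, gives 13 mL.min-1.g-1. Every measured swap at this position stayed within the scatter: a 1.8-fold lower number from compound 1 to compound 2 (0.27 log units; within the scatter), no change at the digits printed from compound 1 to compound 3 (within the scatter) and a 1.8-fold higher number from compound 2 to compound 3 (0.27 log units; within the scatter). Compound 4, `Cn1nccc1-c1cnc(NCc2c(F)ccc3c2CCO3)c2cn[nH]c(=O)c12`, carries the change (1-methyl-1H-pyrazol-5-yl in place of 1-methyl-2-(methylcarbamoyl)-1H-imidazol-5-yl on an aromatic carbon). Given those three steps, compound 4 is expected to show no movement beyond the scatter. Compound 4 is therefore estimated at 22 mL.min-1.g-1, in the range 10 mL.min-1.g-1 to 45 mL.min-1.g-1, which means an expected step of a 1.1-fold lower number from compound 3 to compound 4 (0.04 log units; within the scatter).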

Compound 4, intrinsic clearance in microsomes in the Homo sapiens assay: 14 mL.min-1.g-1
For compound 4 the middle estimate is 1.6-fold (0.20 log units) above the measured one, and the stated range covers the measured number.
By their numbers in the Homo sapiens assay, from the lowest: compounds 2, 4, 1 and 3 (each within the scatter of the next).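

In the Homo sapiens assay this position still shows no step beyond the scatter, even with 1-methyl-1H-pyrazol-5-yl, the group with the fewest heavy atoms so far: a 1.7-fold lower number from compound 3 to compound 4 (0.23 log units; within the scatter), a 1.1-fold higher number from compound 2 to compound 4 (0.03 log units; within the scatter) and a 1.7-fold lower number from compound 1 to compound 4 (0.23 log units; within the scatter). In a physicochemical assay for solubility, read by LC-MS, in phosphate buffer, with a stated time of 24 h, at pH 7.4 (on this read-out higher numbers stand for higher solubility and lower numbers for lower solubility), however, the swap that leaves 1-methyl-2-(methylcarbamoyl)-1H-imidazol-5-yl behind does go beyond the scatter, a 2.5-fold lower number from compound 3 to compound 4 (0.40 log units; beyond the scatter). In the physicochemical assay compound 3 gives 5000 nM and compound 4 gives 2000 nM.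

This swap changes both the ring and the methylcarbamoyl, so the compounds shown cannot separate the two. As far as these compounds go, whether a carboxylic acid or a primary amine here would move either read-out further remains open.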